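Swapping an amide for a benzoyl group on an indole acrylonitrile

The compounds below may be only part of what the source reports. "The series", "measured", "known", "first", "only" and "open" are said of these compounds alone.

For the measured compounds named here, compound 1 `N#C/C(=C\c1c(-c2ccccc2)[nH]c2ccccc12)C(N)=O` is the only compound here with a numbered result: in a functional assay on MT4 cells (Homo sapiens) for antiproliferative activity, read by MTT assay, with a stated time of 96 h (on this read-out lower numbers stand for an effect already at smaller amounts and higher numbers for an effect only at larger amounts of compound), compound 1 gives 6000 nM. A close relative, compound 2 `N#C/C(=C\c1c[nH]c2ccccc12)S(=O)(=O)c1ccccc1`, has a different substitution and was also tested. In this assay compound 2 reaches only the limit of > 100000 nM, which is a boundary of the assay rather than a number. So compound 1 stands as the one measured value, while the other entry is a limit (the limit of > 100000 nM in this assay, at which 1 of the 2 values shown sits).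

Compound 3 `N#C/C(=C\c1c(-c2ccccc2)[nH]c2ccccc12)C(=O)c1ccccc1` is not yet measured. It differs from compound 1 in one place: phenyl in place of amino on a carbonyl carbon. Going by the values given here, no pair of measured compounds shows this kind of change, so the expected step rests only on the structures. My expectation is a modest move toward an effect at smaller amounts, a step from compound 1 to compound 3 of a 2.0-fold lower number from compound 1 to compound 3 (0.30 log units; within the scatter) in this assay. Compound 3 is therefore estimated at 3000 nM, with a range from 600 nM to 15000 nM.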

Compound 3, half-maximal effective concentration: 500 nM
Compound 3: middle estimate off by 6.0-fold (0.78 log units), on the high side; measured number below the stated range.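

Going from carbamoyl to benzoyl gives a 12-fold lower number from compound 1 to compound 3 (1.08 log units; beyond the scatter) in this assay, so the group on this carbonyl carbon has a strong bearing on the read-out. For the compounds shown here, this is the first reading at this place in the molecule, and it shows that amino, with its hydrogen-bond donor, is not needed for an effect, since compound 3 carries a phenyl ring there and has no such donor in that group. Nothing measured here accounts for the size of this step.

From the compounds shown here alone, whether the gain needs an aromatic ring or only the loss of amino stays open, and a methyl group or a carboxylic acid on the same carbonyl carbon would help to separate the two. Going by these compounds, how far the gain could go with a chlorine or a methoxy group on the benzoyl ring also stays open.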